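Changing the Amide to a Urea on an Iodophenyl Sulfonate

The compounds below may be only part of what the source reports. "The series", "measured", "known", "first", "only" and "open" are said of these compounds alone.

Of the compounds shown here, three have been measured in a functional assay on HT-1080 cells (Homo sapiens) for antiproliferative activity, read by sulforhodamine B assay, with a stated time of 48 h; a lower number here means a stronger inhibitor, a higher number a weaker inhibitor. Compound 1 `CC(C)c1ccccc1OS(=O)(=O)c1cccc(NC(=O)CCl)c1` gives 780 nM. Compound 2 `CCCC(=O)Nc1ccc(S(=O)(=O)Oc2ccccc2C(C)C)cc1` gives 950 nM. Compound 3 `CCCC(=O)Nc1ccc(S(=O)(=O)Oc2ccccc2I)cc1` gives 2000 nM. Compound 3 differs from compound 2 in a single place, iodo in place of isopropyl on an aromatic carbon, and that one swap produced a 2.1-fold higher number from compound 2 to compound 3 (0.32 log units; beyond the scatter). Within the data shown here, on the numbers so far, compound 3 therefore stands highest, which makes it the weakest inhibitor of the three, with compound 2 nearest to it and compound 1 furthest away.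

Compound 4 `O=C(Nc1ccc(S(=O)(=O)Oc2ccccc2I)cc1)NC1CC1` keeps the iodo-bearing core of compound 3 and alters the other end of the molecule instead: cyclopropylamino in place of propyl on a carbonyl carbon. Cut one bond further out, the same change reads as propylcarbonyl becoming cyclopropylcarbamoyl, so a simple amide becomes a urea.

Among the measured compounds shown here, none of the measured steps bears on this kind of change. For the measured compounds named here, the only single-point step seen so far concerns the aromatic substituent, and compound 1 differs from the other two in more than one place, so nothing here isolates the effect of reshaping the chain on the carbonyl carbon. Going by the values given here, with no guiding precedent, the expected step of no change at the digits printed from compound 3 to compound 4 (within the scatter) is none beyond the scatter, though the range must be wide. Compound 4 is therefore estimated at 2000 nM, with a likely span from 600 nM to 6500 nM.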

Compound 4, half-maximal inhibitory concentration: 1300 nM
Estimate against measurement, compound 4: 1.5-fold (0.19 log units) above; the measured number falls inside the stated range.
By their numbers in this assay, from the lowest: compounds 1, 2, 4 and 3 (each within the scatter of the next, the first and the last beyond it).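

In this assay, putting cyclopropylamino in place of propyl on the carbonyl carbon gives a 1.5-fold lower number from compound 3 to compound 4 (0.19 log units; within the scatter) and so leaves the two compounds indistinguishable, even though this swap turns an amide into a urea, adds a nitrogen and a three-membered ring, and brings in a hydrogen-bond donor. Among these compounds, this is the first look at this end of the molecule, and on the iodo-bearing core the reshaped chain on the carbonyl carbon is accommodated without a measurable loss or gain, unlike the aromatic swap that gave a 2.1-fold higher number from compound 2 to compound 3 (0.32 log units; beyond the scatter) and lies beyond the scatter. No measurement available here explains why these two compounds read alike.

Compound 4 is the only urea shown, so it remains open whether the same change would read the same way with isopropyl on the aromatic carbon in place of iodo. Also open, on these data alone, is how far this tolerance extends, for example to a longer chain such as hexyl, to a phenyl ring, or to a dimethylamino group on the same carbonyl carbon.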